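Replacing 2,6-dimethoxyphenyl with 1H-indol-3-yl in a growth assay

The source may hold more compounds than are shown below. What is called first, only, known or untested is meant among the compounds shown, and "the series" means these compounds.

In a functional assay on DU-145 cells (Homo sapiens) for inhibition, read by trypan blue exclusion, with a stated time of 96 h (a higher number here means a weaker inhibitor of growth, a lower number a stronger inhibitor of growth), compound 1 (`O=C(/C(=C\c1csc([N+](=O)[O-])c1)S(=O)(=O)c1ccc(Br)cc1)c1ccc(Br)cc1`) gives 1000 nM and compound 2 (`COc1cccc(OC)c1/C=C(\C(=O)c1ccc(Br)cc1)S(=O)(=O)c1ccc(Br)cc1`) gives 10000 nM as the higher of the two numbers, which makes it the weaker growth inhibitor of this pair. The next compound to be tested is compound 3 (`O=C(/C(=C\c1c[nH]c2ccccc12)S(=O)(=O)c1ccc(Br)cc1)c1ccc(Br)cc1`). It differs from compound 2 as follows: 1H-indol-3-yl in place of 2,6-dimethoxyphenyl on a double-bonded chain carbon bound to a double-bonded chain carbon. In words, this is 1H-indol-3-yl in place of 2,6-dimethoxyphenyl on a double-bonded chain carbon bound to a double-bonded chain carbon.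

For the measured compounds named here, only one measured step bears on this change, and it concerns the same place on the shared core: a 10-fold higher number from compound 1 to compound 2 (1.00 log units; beyond the scatter). Read in reverse, that step shows a lower number when 2,6-dimethoxyphenyl is absent, but 5-nitrothiophen-3-yl is the group there, and no measured compound yet carries 1H-indol-3-yl. A fall in the number is therefore expected in this assay, though only part of the way towards compound 1. The expected change is a 4.0-fold lower number from compound 2 to compound 3 (0.60 log units; beyond the scatter), with considerable uncertainty. For compound 3 the estimated value is 2500 nM, within an expected range of 500 nM to 10000 nM.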

Compound 3, concentration for 50% growth inhibition: 25000 nM
Beside the measured number, compound 3's estimate is 10-fold (1.00 log units) below it; measured number outside the range, above it.
By their numbers in this assay, from the lowest: compound 1; then compound 2; then compound 3.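

In this assay, 1H-indol-3-yl brings no gain over 2,6-dimethoxyphenyl on a double-bonded chain carbon bound to a double-bonded chain carbon: the change gives a 2.5-fold higher number from compound 2 to compound 3 (0.40 log units; beyond the scatter) and extends the range of values seen at this place. Set against 5-nitrothiophen-3-yl, the same group gives a 25-fold higher number from compound 1 to compound 3 (1.40 log units; beyond the scatter), the largest step among the three compounds, so compound 1 stands as the strongest growth inhibitor of the three and compound 3 as the weakest. The gain of a hydrogen-bond donor and the loss of hydrogen-bond acceptors from compound 2 to compound 3 therefore go with a higher number here, but the ring system changes in the same step, so this single pair cannot separate these features, and nothing at hand explains the rise.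

As far as these compounds go, it remains open whether 1-methylindol-3-yl, which lacks the indole hydrogen, would restore or further weaken growth inhibition at this place. The compounds shown also leave open whether the lower number of compound 1 would survive in an unsubstituted thiophen-3-yl or be matched by a 4-nitrophenyl group.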